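A few compounds are considered here, and "the series" means these few. Any claim that something is new, unique, unknown or untested is made for them only; others in the source may bear on it.

Going by the values given here, compound 3 `C=C1C(=O)[C@]23C[C@@]1(O)CC[C@H]2c1ccc(OS(=O)(=O)c2ccc(C)cc2)c(C)c1[C@@H]3Cn1cc(-c2ccc(F)cc2)nn1` sits at the high end of the three numbers measured so far in a functional assay on HL-60 cells (Homo sapiens) for cytotoxicity, read by MTT assay, with a stated time of 4 days; a higher number here means a weaker inhibitor, a lower number a stronger inhibitor: compound 3 gives 1290 nM. Compound 1 `C=C1C(=O)[C@]23C[C@@]1(O)CC[C@H]2c1ccc(OS(=O)(=O)c2ccc(C)cc2)c(C)c1[C@@H]3Cn1cc(-c2ccc(C)cc2)nn1` gives 1110 nM in this assay, which is within the scatter of compound 3, so the two cannot be told apart. Among the compounds with values here, compound 2 `C=C1C(=O)[C@]23C[C@@]1(O)CC[C@H]2c1ccc(O)c(C)c1[C@@H]3Cn1cc(-c2ccc(Br)cc2)nn1` gives 560 nM in this assay, and this number lies beyond the scatter below compound 3; compound 2, however, also carries a free hydroxyl where compounds 1 and 3 carry the tosylate, so no single-point step links it to compound 3.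

Compound 4 `C=C1C(=O)[C@]23C[C@@]1(O)CC[C@H]2c1ccc(OS(=O)(=O)c2ccc(C)cc2)c(C)c1[C@@H]3Cn1cc(-c2ccc(Br)cc2)nn1` differs from compound 3 only at the phenyl on the triazole: bromo in place of fluoro on an aromatic carbon

Within the data shown here, the one measured step at this same position is a 1.2-fold higher number from compound 1 to compound 3 (0.07 log units; within the scatter), which did not move the number beyond the scatter. The bromo substituent of compound 2 appears only together with the other change, so its own weight cannot be read. Among the measured compounds shown here, with the only comparable step being flat, the step in this assay is expected to be small, a 1.1-fold lower number from compound 3 to compound 4 (0.03 log units; within the scatter), in no firm direction. Compound 4 is therefore estimated at 1200 nM in this assay, with a range from 600 nM to 2400 nM.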

Compound 4, half-maximal inhibitory concentration: 1020 nM
The estimate for compound 4 lay 1.2-fold (0.07 log units) above the measured number; the range from low to high includes it.
By their numbers in this assay, from the lowest: compounds 2, 4, 1 and 3 (each within the scatter of the next, the first and the last beyond it).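

In this assay, the exchange of 4-fluorophenyl for 4-bromophenyl gives a 1.3-fold lower number from compound 3 to compound 4 (0.10 log units; within the scatter) and the exchange of methyl for bromo gives a 1.1-fold lower number from compound 1 to compound 4 (0.04 log units; within the scatter) so that, with the earlier step of a 1.2-fold higher number from compound 1 to compound 3 (0.07 log units; within the scatter) as well, methyl, fluoro and bromo on this aromatic carbon cannot be told apart while the tosylate is present. Going by these compounds alone, compound 4 also gives the first single-point reading of the change on the oxygen, whose weight could not be separated from that of the other change before: (4-methylphenyl)sulfonyl in place of hydrogen gives a 1.8-fold higher number from compound 2 to compound 4 (0.26 log units; within the scatter) and so stays within the scatter in the bromo pair. The data shown offer nothing that accounts for these readings.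

The compounds shown leave open whether an amine or a carboxylic acid on this same aromatic carbon would move the number beyond the scatter, as none of the three substituents here does. They also leave open whether the change on the oxygen would read the same with fluoro or methyl on the ring, and whether a methyl ether there would differ from either the free hydroxyl or the tosylate.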